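What a 3-chlorophenyl swap may do to compound 3

The compounds below may be only part of what the source reports. "The series", "measured", "known", "first", "only" and "open" are said of these compounds alone.

compound 1 `FC(F)(F)c1ccc(-c2ccc(-c3ccc(-c4nc5ccccc5[nH]4)cc3)cc2)cc1` gives 100000 nM
compound 2 `Oc1ccc(-c2ccc(-c3ccc(-c4nc5ccccc5[nH]4)cc3)cc2)cc1` gives 47200 nM
compound 3 `COc1ccc(-c2ccc(-c3ccc(-c4nc5ccccc5[nH]4)cc3)cc2)cc1` gives 100000 nM

In a functional assay on HOP-62 cells (Homo sapiens) for inhibition, read by sulforhodamine B assay (a lower number here means a stronger inhibitor of growth, a higher number a weaker inhibitor of growth), compound 3 gives 100000 nM and stands level with compound 1 at the highest number of the three, with only compound 2 lower. The next molecule, compound 4 `Clc1cccc(-c2ccc(-c3ccc(-c4nc5ccccc5[nH]4)cc3)cc2)c1`, has 3-chlorophenyl in place of 4-methoxyphenyl on an aromatic carbon, a change counted as 3-chlorophenyl in place of 4-methoxyphenyl on an aromatic carbon and not yet tested.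

Among the measured compounds shown here, none of the measured compounds carries chlorine, so the earlier steps offer only indirect guidance. Changing the group at the end of the molecule has so far done little. There is a 2.1-fold lower number from compound 1 to compound 2 (0.33 log units; beyond the scatter) and then a 2.1-fold higher number from compound 2 to compound 3 (0.33 log units; beyond the scatter) as the hydroxy group is capped with methyl. Only compound 2 carries a hydroxy group. Compound 4 lacks one, as do the two compounds that show no change at the digits printed from compound 1 to compound 3 (within the scatter) in their comparison, so it is expected to stay close to them.

In this assay the expected step is a 1.3-fold lower number from compound 3 to compound 4 (0.10 log units; within the scatter) and no real shift beyond the scatter is expected. Compound 4 is estimated at 80000 nM with an expected range from 30000 nM to 100000 nM for its measurement.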

Compound 4, concentration for 50% growth inhibition: 100000 nM
Estimate against measurement, compound 4: 1.3-fold (0.10 log units) below, and the stated range covers the measured number.
By their numbers in this assay, from the lowest: compound 2; then compounds 1, 3 and 4 (each within the scatter of the next).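

In this assay, among the compounds shown here, 3-chlorophenyl in place of 4-methoxyphenyl on this aromatic carbon, para to a large group, gives no change at the digits printed from compound 3 to compound 4 (within the scatter), and this is the first sign that a chlorine-bearing end ring reads the same as the methoxy compound. The same holds against the trifluoromethyl compound, with no change at the digits printed from compound 1 to compound 4 (within the scatter), while 3-chlorophenyl in place of 4-hydroxyphenyl gives a 2.1-fold higher number from compound 2 to compound 4 (0.33 log units; beyond the scatter), so among these four compounds only compound 2, the one with a hydroxy group, stands apart, and none of the other three goes against that reading. Nothing measured for these compounds offers an explanation for this result.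

Compound 2 is a single example, so the compounds shown leave open whether its modest step belongs to the hydroxy group alone or would also appear with an amine or a carboxylic acid on the end ring. They also leave open whether a longer chain at this position, such as one ending in an amine, would move the number any further from what compounds 1, 3 and 4 show.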